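Two substitutions on a shared core, one combination pending

A few compounds are considered here, and "the series" means these few. Any claim that something is new, unique, unknown or untested is made for them only; others in the source may bear on it.

The series rests on compound 1 `Clc1cccc(-c2ccc(-c3ccc(-c4nc5ccccc5[nH]4)cc3)cc2)c1`, measured in a functional assay on KB cells (Homo sapiens) for inhibition, read by sulforhodamine B assay (a higher number here means a weaker inhibitor of growth, a lower number a stronger inhibitor of growth), where compound 1 gives 32300 nM. Two single changes branch from it. Compound 2 `COc1ccc(-c2ccc(-c3ccc(-c4nc5ccccc5[nH]4)cc3)cc2)cc1OC` differs by 3,4-dimethoxyphenyl in place of 3-chlorophenyl on an aromatic carbon and in this assay compound 2 gives 9250 nM; the step is a 3.5-fold lower number from compound 1 to compound 2 (0.54 log units; beyond the scatter). Compound 3 `Oc1cccc2[nH]c(-c3ccc(-c4ccc(-c5cccc(Cl)c5)cc4)cc3)nc12` differs from compound 1 by hydroxy in place of hydrogen on an aromatic carbon, which is also how the core of compound 3 differs from that of compound 1 and compound 2; in this assay compound 3 gives 2280 nM, and the step is a 14-fold lower number from compound 1 to compound 3 (1.15 log units; beyond the scatter). Compound 3 holds the lowest of the three numbers, with both of its steps to the others beyond the scatter.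

Compound 4 `COc1ccc(-c2ccc(-c3ccc(-c4nc5c(O)cccc5[nH]4)cc3)cc2)cc1OC` is not yet measured. It differs from compound 3 by 3,4-dimethoxyphenyl in place of 3-chlorophenyl on an aromatic carbon, the same change already seen from compound 1 to compound 2, at a place described in the same words, so the two are the same change applied to cores that differ by the hydroxy just described. If the change carries over as it did in a 3.5-fold lower number from compound 1 to compound 2 (0.54 log units; beyond the scatter), the expected step is a 3.3-fold lower number from compound 3 to compound 4 (0.51 log units; beyond the scatter). That expectation rests on a single measured pair, so the range is kept wide. For compound 4 in this assay the estimate is 700 nM, expected to lie between 250 nM and 2000 nM.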

Compound 4, concentration for 50% growth inhibition: 2710 nM
Beside the measured number, compound 4's estimate is 3.9-fold (0.59 log units) below it, outside the stated range (above it).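

In this assay, 3,4-dimethoxyphenyl in place of 3-chlorophenyl on the core of compound 3 gives a 1.2-fold higher number from compound 3 to compound 4 (0.08 log units; within the scatter), so the two compounds cannot be told apart, and the change does not carry over at the size it had on the core of compound 1: the same change on two cores in this assay, a 3.5-fold lower number (0.54 log units; beyond the scatter) from compound 1 to compound 2 and a 1.2-fold higher number (0.08 log units; within the scatter) from compound 3 to compound 4, 4.2-fold (0.62 log units) apart, beyond the scatter of two such steps. Seen from the other side, hydroxy in place of hydrogen still gives a 3.4-fold lower number from compound 2 to compound 4 (0.53 log units; beyond the scatter), but this step is smaller than the one on the 3-chlorophenyl compounds: the same change on two cores in this assay, a 14-fold lower number (1.15 log units; beyond the scatter) from compound 1 to compound 3 and a 3.4-fold lower number (0.53 log units; beyond the scatter) from compound 2 to compound 4, 4.2-fold (0.62 log units) apart, beyond the scatter of two such steps. Both comparisons come from the same four compounds, so they show that the two changes do not add within this set, but they do not show why, or whether the same holds for any other pair of changes in the series.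

The compounds shown leave open whether the two changes would also fail to add if an amine or a methoxy took the place of the hydroxy, or if a single methoxy or a fluorine took the place of the groups on the terminal phenyl ring. They also leave open whether any group on the hydroxy core can reach a lower number than those of compound 3 and compound 4.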